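The source may hold more compounds than are shown below. What is called first, only, known or untested is meant among the compounds shown, and "the series" means these compounds.

Going by the values given here, of the two numbers measured so far, compound 2 `COc1ccccc1-c1ccc(COCCCCCN2C[C@H](O)[C@@H](O)[C@H](O)[C@H]2CO)cc1` gives 3 nM in an assay on isolated protein for inhibition of Beta-glucosidase (Homo sapiens) (a higher number here means a weaker inhibitor, a lower number a stronger inhibitor), and compound 1 `Cc1cccc(-c2ccc(COCCCCCN3C[C@H](O)[C@@H](O)[C@H](O)[C@H]3CO)cc2)c1` gives 2 nM, the two within the scatter of each other. Among the compounds with values here, the one known step, a 1.5-fold higher number from compound 1 to compound 2 (0.18 log units; within the scatter), also lies within the scatter. Compound 3 `OC[C@@H]1[C@@H](O)[C@H](O)[C@@H](O)CN1CCCCCOCc1ccc(-c2ccc(C(F)(F)F)cc2)cc1` is not yet measured; it differs from compound 2 by 4-(trifluoromethyl)phenyl in place of 2-methoxyphenyl on an aromatic carbon. Within the data shown here, only that one step bears on this change, and it was small, so no step beyond the scatter is expected in this assay this assay. Compound 3 is therefore estimated at 3 nM, between 1 nM and 10 nM, an expected step of no change at the digits printed from compound 2 to compound 3 (within the scatter).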

Compound 3, half-maximal inhibitory concentration: 10 nM
Estimate against measurement, compound 3: 3.3-fold (0.52 log units) below; the range from low to high includes it.
By their numbers in this assay, from the lowest: compounds 1 and 2 (each within the scatter of the next); then compound 3.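

The group at this place can move the number in this assay beyond the scatter, which the earlier pair did not show. Putting in 4-(trifluoromethyl)phenyl brings a 3.3-fold higher number from compound 2 to compound 3 (0.52 log units; beyond the scatter) and likewise a 5.0-fold higher number from compound 1 to compound 3 (0.70 log units; beyond the scatter) when the starting group differs. Both steps are modest, so this place accepts the new group with only a limited loss.

On these data alone, whether the change comes from the trifluoromethyl group itself or from where it sits stays open, as does the effect of an amine or a carboxylic acid here. Nothing at hand explains the shift.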